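A few compounds are considered here, and "the series" means these few. Any claim that something is new, unique, unknown or untested is made for them only; others in the source may bear on it.

Working notes on the series. Going by the values given here, in a functional assay (mast cells) for inhibition, with Rattus norvegicus as the target (a higher number here means that more compound is needed for the effect, a lower number that less compound is needed), compound 2 (`CC1CC/C(=N\Nc2cccc(Cl)c2)c2ncc(C(=O)O)c(=O)n21`) gives 311000 nM and holds the highest of the three numbers so far. The nearest number belongs to compound 1 (`CCOC(=O)c1cnc2n(c1=O)C(C)CC/C2=N\Nc1ccc(C(=O)O)cc1`) with 66000 nM as its value, and the furthest belongs to compound 3 (`CCOc1ccc(N/N=C2\CC[C@@H](C)n3c2ncc(C(=O)O)c3=O)cc1`) with 1000 nM as its value. Both gaps lie beyond the scatter, and compound 2 therefore needs the most compound of the three for the effect.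

The next entry is compound 4 (`Cc1ccc(N/N=C2\CCC(C)n3c2ncc(C(=O)O)c3=O)cc1`), not yet measured. The change from compound 2 reads 4-methylphenyl in place of 3-chlorophenyl on an amine nitrogen and amounts to 4-methylphenyl in place of 3-chlorophenyl on an amine nitrogen.

Among the compounds with values here, no measured pair isolates a change of this kind, so there is no direct step to carry over. The expectation rests only on the spread of values, with compound 2 at the top and the two other measured compounds well under it. A replacement on this nitrogen is therefore more likely to lower the number than to raise it, though the data cannot confirm this.

The estimated step of a 39-fold lower number from compound 2 to compound 4 (1.59 log units; beyond the scatter) is a drop beyond the scatter, with a wide margin. For compound 4 the expected value in this assay is 8000 nM (estimated range 1000 nM to 60000 nM).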

Compound 4, half-maximal effective concentration: 280 nM
For compound 4 the middle estimate is 29-fold (1.46 log units) above the measured one, outside the stated range (below it).
By their numbers in this assay, from the lowest: compound 4; then compound 3; then compound 1; then compound 2.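

In this assay, 4-methylphenyl in place of 3-chlorophenyl on an amine nitrogen gives a 1100-fold lower number from compound 2 to compound 4 (3.05 log units; beyond the scatter), a large step and the only one in the series that isolates a single place, so the strong dependence of the number on this aryl group is now observed directly and no longer inferred from the spread of values. The two groups match in everything counted for them: the same number of heavy atoms, one six-membered aromatic ring of carbon only, no hydrogen-bond donors or acceptors and no net charge, so these counts do not distinguish them, and the difference lies in the substituent and where it sits on the ring. Nothing measured here bears on the reason for the size of this step.

The step changes the substituent and its place on the ring together, and the compounds shown do not separate these two contributions. A plain phenyl group on the same nitrogen, or a pyridyl ring there, would help show how much of the step belongs to the chlorine atom, to the methyl group, or to the ring itself.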